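The source may report more compounds than this note shows. Statements on the series, on what has been measured and on what is new or still open speak of the compounds shown alone.

In an ADME assay on THP-1 cells (Homo sapiens) for cytotoxicity (on this read-out higher numbers stand for lower toxicity in this test and lower numbers for higher toxicity in this test), the compounds measured so far read as follows:
- compound 1 (`CC(C)(C)Nc1c(-c2ccccn2)nc2c(OCc3ccccc3)cccn12`) gives > 50000 nM as a limit
- compound 2 (`Cc1ccc2nc(-c3ccccn3)c(Nc3ccc4c(c3)OCCO4)n2c1`) gives 16000 nM as a number
- compound 3 (`CN(C)CCNc1c(-c2ccccn2)nc2ccccn12`) gives > 50000 nM as a limit

Compound 3 stands at the limit of > 50000 nM in this assay, at which 2 of the 3 values shown sit, and so carries a limit, not a number. The next compound to be read is compound 4 (`c1ccc(CNc2c(-c3ccccn3)nc3ccccn23)cc1`). Compared with compound 3, it has phenyl in place of (dimethylamino)methyl on a saturated chain carbon bound to a nitrogen on an aromatic ring. Cut one bond further out, the same difference reads 2-(dimethylamino)ethyl to benzyl.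

Within the data shown here, the series offers no measured step between close neighbours, so the size of this change rests on the values alone. Among the measured compounds shown here, compound 2 is the only compound with a number, at 16000 nM in this series, and it shows that a number can be read on this core. Compound 1, which also lacks the dimethylamino group, stays at the limit > 50000 nM as well, so a large change is not expected. The step of an at least 1.4-fold lower number from compound 3 to compound 4 (0.15 log units; that floor lies within the scatter) is expected to be modest and towards lower numbers, and it may not be visible at all if the assay again reports a limit. The estimated value for compound 4 is 35000 nM with an expected range of 13000 nM to 70000 nM in this read-out.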

Compound 4, half-maximal cytotoxic concentration: > 50000 nM
Compound 4: only a limit was reported; the forecaster's own chance of this, stated with the estimate: 50%; middle value at least 1.4-fold (0.15 log units) away from the limit.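

In this assay, compound 3 and compound 4 both stand at a limit and not at a number, so no step can be read between them: the limit of > 50000 nM in this assay, at which 3 of the 4 values shown sit.

The compounds shown leave open the size and direction of any effect of phenyl in place of (dimethylamino)methyl in this assay.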